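A few compounds are considered here, and "the series" means these few. Any claim that something is new, unique, unknown or untested is made for them only; others in the source may bear on it.

In a functional assay on BE(2)-C cells (Homo sapiens) for inhibition, read by MTT assay, with a stated time of 72 h (a lower number here means a stronger inhibitor of growth, a higher number a weaker inhibitor of growth), compound 1 `O=S(=O)(NCCCNCc1ccc(Cl)cc1)c1cc(C(F)(F)F)cc(C(F)(F)F)c1` gives 2900 nM, the second highest of three numbers. Compound 2 `O=S(=O)(NCCCNCC1COc2ccccc2O1)c1cc(C(F)(F)F)cc(C(F)(F)F)c1` gives 2800 nM in this assay, and compound 3 `O=S(=O)(NCCCNCc1ccc(Cl)c(C(F)(F)F)c1)c1cc(C(F)(F)F)cc(C(F)(F)F)c1` gives 8600 nM. The move a 1.0-fold lower number from compound 1 to compound 2 (0.02 log units; within the scatter) shows that a swap at the chain carbon bound to the amine nitrogen can leave the number where it was, whereas a 3.0-fold higher number from compound 1 to compound 3 (0.47 log units; beyond the scatter) and a 3.1-fold higher number from compound 2 to compound 3 (0.49 log units; beyond the scatter) show modest rises. Compound 4 `CN(CCCNS(=O)(=O)c1cc(C(F)(F)F)cc(C(F)(F)F)c1)Cc1ccccc1` differs from compound 1 by benzyl(methyl)amino in place of (4-chlorobenzyl)amino on a saturated chain carbon, three bonds along the chain from a sulfonamide nitrogen. Among the measured compounds shown here, no measured step removes the chlorine or adds a methyl at that nitrogen, so the nearest guide is the flat step of compound 1 to compound 2. He therefore expects a 1.1-fold higher number from compound 1 to compound 4 (0.04 log units; within the scatter), within the scatter, and estimates for compound 4 a value of 3200 nM, ranging from 1300 nM to 8000 nM.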

Compound 4, concentration for 50% growth inhibition: 28000 nM
Beside the measured number, compound 4's estimate is 8.8-fold (0.94 log units) below it; the measured number lies above the stated range.
By their numbers in this assay, from the lowest: compounds 2 and 1 (each within the scatter of the next); then compound 3; then compound 4.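

Going from (4-chlorobenzyl)amino to benzyl(methyl)amino gives a 9.7-fold higher number from compound 1 to compound 4 (0.98 log units; beyond the scatter), so this position is less forgiving than a 1.0-fold lower number from compound 1 to compound 2 (0.02 log units; within the scatter) had suggested. The entering group has 0 hydrogen-bond donors against 1 in the group it replaces and also lacks the chlorine, so two things change at once and this step cannot separate them. No evidence available here explains the rise. 

The compounds shown leave open whether plain benzylamino, with neither chlorine nor methyl, would stay near compound 1 or fall near compound 4. They also leave open how (4-chlorobenzyl)(methyl)amino would behave.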